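A Chloro for Fluoro Swap on a Weaker Core

The compounds below may be only part of what the source reports. "The series", "measured", "known", "first", "only" and "open" are said of these compounds alone.

Compound 1 `Cc1ccc(-c2nn(-c3ccccc3)cc2C(=O)NOCc2ccccc2F)cc1` and compound 2 `Cc1ccc(-c2nn(-c3ccccc3)cc2C(=O)NOCc2ccccc2Cl)cc1` share a core and differ only by chloro in place of fluoro on an aromatic carbon. In a functional assay on A549 cells (Homo sapiens) for antiproliferative activity, read by MTT assay, with a stated time of 48 h, in the presence of a further agent that is not named here (a lower number here means a stronger inhibitor of growth, a higher number a weaker inhibitor of growth), compound 1 gives 260 nM and compound 2 gives 380 nM, so the step of a 1.5-fold higher number from compound 1 to compound 2 (0.16 log units; within the scatter) is small. Compound 3 `O=C(NOCc1ccccc1F)c1cn(-c2ccccc2)nc1-c1ccc(Cl)cc1` carries a different core, the difference from compound 1 being (chloro in place of methyl on an aromatic carbon); in this assay compound 3 gives 12100 nM, a step of a 47-fold higher number from compound 1 to compound 3 (1.67 log units; beyond the scatter). Compound 4 `O=C(NOCc1ccccc1Cl)c1cn(-c2ccccc2)nc1-c1ccc(Cl)cc1` has not yet been measured. It differs from compound 3 by chloro in place of fluoro on an aromatic carbon, the same change that separates compound 1 from compound 2, at the same place. Because the earlier step was a 1.5-fold higher number from compound 1 to compound 2 (0.16 log units; within the scatter), a similarly small step is expected here, a 1.2-fold higher number from compound 3 to compound 4 (0.09 log units; within the scatter). Compound 4 is therefore estimated at 15000 nM in this assay, with a likely range from 6000 nM to 40000 nM.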

Compound 4, concentration for 50% growth inhibition: 15500 nM
For compound 4 the middle estimate is 1.0-fold (0.01 log units) below the measured one, and the stated range covers the measured number.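

Chloro in place of fluoro gives a 1.3-fold higher number from compound 3 to compound 4 (0.11 log units; within the scatter) in this assay, so the small step seen on the core of compound 1 also appears on the core of compound 3: the same change on two cores in this assay, a 1.5-fold higher number (0.16 log units; within the scatter) from compound 1 to compound 2 and a 1.3-fold higher number (0.11 log units; within the scatter) from compound 3 to compound 4, 1.1-fold (0.06 log units) apart, within the scatter of two such steps. Chloro in place of methyl gives a 41-fold higher number from compound 2 to compound 4 (1.61 log units; beyond the scatter), so this large step appears with either 2-fluorobenzyl or 2-chlorobenzyl present: the same change on two cores in this assay, a 47-fold higher number (1.67 log units; beyond the scatter) from compound 1 to compound 3 and a 41-fold higher number (1.61 log units; beyond the scatter) from compound 2 to compound 4, 1.1-fold (0.06 log units) apart, within the scatter of two such steps. Each change therefore carries over between these two cores, but these compounds do not show that it would do so on any other core or in any other test.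

As far as these compounds go, it remains open how a bromo group would compare with fluoro and chloro at that place on the benzyl group. From the compounds shown here alone, it also remains open whether an amine or a carboxylic acid in place of the methyl would keep the growth inhibition of compound 1.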